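The source may hold more compounds than are shown below. What is called first, only, known or untested is meant among the compounds shown, and "the series" means these compounds.

Of the compounds shown here, three sharing one core have been read in a functional assay on A549 cells (Homo sapiens) for antiproliferative activity, read by MTT assay; a lower number here means a stronger inhibitor, a higher number a weaker inhibitor. Compound 1 (`Cc1cccc(/C=N/Nc2ncc3c(n2)n(C2CCCC2)c(=O)c(=O)n3C)c1`) gives 34500 nM, compound 2 (`Cn1c(=O)c(=O)n(C2CCCC2)c2nc(N/N=C/c3ccc(F)c(Cl)c3)ncc21`) gives 9410 nM, and compound 3 (`Cn1c(=O)c(=O)n(C2CCCC2)c2nc(N/N=C/c3ccc(O)c(Br)c3)ncc21`) gives 12800 nM. Compound 3 therefore stands with compound 2, as the data show a 1.4-fold higher number from compound 2 to compound 3 (0.13 log units; within the scatter) but also a 2.7-fold lower number from compound 1 to compound 3 (0.43 log units; beyond the scatter).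

Compound 4 (`Cn1c(=O)c(=O)n(C2CCCC2)c2nc(N/N=C/c3ccccc3Cl)ncc21`) has not yet been measured. Its change is 2-chlorophenyl in place of 3-bromo-4-hydroxyphenyl on a carbon with a double bond to nitrogen, with 2-chlorophenyl in place of 3-bromo-4-hydroxyphenyl on a carbon with a double bond to nitrogen. Going by the values given here, the measured steps at this place offer the only guide, and the largest is a 3.7-fold lower number from compound 1 to compound 2 (0.56 log units; beyond the scatter), which is modest. Among the compounds with values here, no measured compound carries 2-chlorophenyl. Its phenyl holds only the chlorine, much as the phenyl of compound 1 holds only the methyl, and compound 1 stands at 34500 nM. A step toward a higher number in this assay is therefore expected, no larger than those measured and possibly within the scatter. The estimated change is a 1.4-fold higher number from compound 3 to compound 4 (0.15 log units; within the scatter). For compound 4 the expected value is 18000 nM, with an estimated range of 7000 nM to 42000 nM.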

Compound 4, half-maximal inhibitory concentration: 9860 nM
Compound 4: the middle estimate sits 1.8-fold (0.26 log units) above what was measured, within the range that was stated.
By their numbers in this assay, from the lowest: compounds 2, 4 and 3 (each within the scatter of the next); then compound 1.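

In this assay, a phenyl holding a single substituent does not by that fact stay with compound 1: 2-chlorophenyl in place of 3-methylphenyl gives a 3.5-fold lower number from compound 1 to compound 4 (0.54 log units; beyond the scatter) and joins the group of compound 2 and compound 3. The 3-bromo-4-hydroxyphenyl group, with its hydrogen-bond donor and acceptor, can give way to 2-chlorophenyl, which has neither, in a 1.3-fold lower number from compound 3 to compound 4 (0.11 log units; within the scatter) and the comparison with 3-chloro-4-fluorophenyl gives a 1.0-fold higher number from compound 2 to compound 4 (0.02 log units; within the scatter) so these three compounds cannot be told apart here. No evidence at hand bears on this result.

On these data alone, whether the methyl or its place sets compound 1 apart stays open, as 2-chlorophenyl and 3-methylphenyl differ in both. As far as these compounds go, how an amine or a carboxylic acid on this phenyl would read also remains open.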